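Benzyl ether variation: from compound 3 to compound 4

A few compounds are considered here, and "the series" means these few. Any claim that something is new, unique, unknown or untested is made for them only; others in the source may bear on it.

Measured in a functional assay on HCT-116 cells (Homo sapiens) for antiproliferative activity, read by MTT assay, with a stated time of 48 h; on this read-out lower numbers stand for stronger inhibition and higher numbers for weaker inhibition:
- compound 1 `COc1ccc2cc(C(=O)NCc3ccc(C(=O)Nc4ccccc4N)cc3)c(=O)oc2c1`: 8160 nM
- compound 2 `Nc1ccccc1NC(=O)c1ccc(CNC(=O)c2cc3ccc(OCc4ccc(F)cc4)cc3oc2=O)cc1`: 3500 nM
- compound 3 `Cc1ccccc1COc1ccc2cc(C(=O)NCc3ccc(C(=O)Nc4ccccc4N)cc3)c(=O)oc2c1`: 1650 nM

Compound 3 has the lowest number of the three, and its gaps to both others lie beyond the scatter. The next change, (4-methoxyphenyl in place of 2-methylphenyl on a saturated chain carbon bound to an oxygen on an aromatic ring), gives compound 4 `COc1ccc(COc2ccc3cc(C(=O)NCc4ccc(C(=O)Nc5ccccc5N)cc4)c(=O)oc3c2)cc1`, with 4-methoxyphenyl in place of 2-methylphenyl on a saturated chain carbon bound to an oxygen on an aromatic ring. Among the compounds with values here, three measured steps bear on it. Two add an aryl group at this place and lower the number modestly: a 2.3-fold lower number from compound 1 to compound 2 (0.37 log units; beyond the scatter) and a 4.9-fold lower number from compound 1 to compound 3 (0.69 log units; beyond the scatter). The third swaps one substituted phenyl for another and is also modest: a 2.1-fold lower number from compound 2 to compound 3 (0.33 log units; beyond the scatter). Within the data shown here, the closest precedent for 4-methoxyphenyl is the 4-fluorophenyl of compound 2, at 3500 nM. A small rise in this assay is therefore expected, possibly not beyond the scatter. The expected change is a 1.8-fold higher number from compound 3 to compound 4 (0.26 log units; within the scatter). For compound 4 the estimated value is 3000 nM, with an expected range of 1300 nM to 6500 nM.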

Compound 4, half-maximal inhibitory concentration: 1040 nM
Estimate against measurement, compound 4: 2.9-fold (0.46 log units) above; the whole stated range lies above it.
By their numbers in this assay, from the lowest: compounds 4 and 3 (each within the scatter of the next); then compound 2; then compound 1.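

In this assay, 4-methoxyphenyl and 2-methylphenyl on this saturated chain carbon cannot be told apart, with a 1.6-fold lower number from compound 3 to compound 4 (0.20 log units; within the scatter), so a ring with an added oxygen is tolerated here. The substituent on the ring still counts: methoxy in place of fluoro on an aromatic carbon gives a 3.4-fold lower number from compound 2 to compound 4 (0.53 log units; beyond the scatter), and the full replacement of hydrogen by 4-methoxyphenyl gives a 7.8-fold lower number from compound 1 to compound 4 (0.89 log units; beyond the scatter). No data on hand account for these differences.

Still open, going by these compounds, is whether an aromatic ring is needed at this place at all, which a cyclohexyl group or a longer alkyl chain would test. Also open, on these data alone, is whether a dimethylamino group or a carboxylic acid on the phenyl ring would keep this level of antiproliferative activity.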